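Swapping a butyl for trifluoromethoxy on the aryl ring

The compounds below may be only part of what the source reports. "The series", "measured", "known", "first", "only" and "open" are said of these compounds alone.

Measured compounds:
compound 1 `C=CCCn1c(N[C@@H]2C[C@H](c3ccccc3)CN(C)C2)nc2cc[nH]c2c1=O` gives 1.5 degrees C
compound 2 `CN1C[C@H](Nc2nc3cc[nH]c3c(=O)n2C)C[C@H](c2cccc(Br)c2)C1` gives 7.5 degrees C
compound 3 `CCCCc1ccc([C@H]2C[C@@H](Nc3nc4cc[nH]c4c(=O)n3C)CN(C)C2)cc1` gives 4.6 degrees C

In an assay on isolated protein for binding affinity to histone acetyltransferase KAT2B (Homo sapiens), read by fluorescence, tested at 10 uM (a lower number here means that the compound stabilises the target less, a higher number that the compound stabilises the target more against heat), compound 3 sits second highest of the three, close below compound 2, while compound 1 lies well lower, both gaps beyond the scatter. Compound 4 `CN1C[C@H](Nc2nc3cc[nH]c3c(=O)n2C)C[C@H](c2ccc(OC(F)(F)F)cc2)C1` is not yet measured. It differs from compound 3 in one place: trifluoromethoxy in place of butyl on an aromatic carbon. Nothing measured here tells how such a swap on that ring changes the reading, and the other compounds carry different groups at different places. The step from compound 3 to compound 4 is expected to be small, a number 0.10 degrees C lower from compound 3 to compound 4 (within the scatter), with no clear direction. Compound 4 is thus estimated at 4.5 degrees C, within a range from 2 degrees C to 7 degrees C.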

Compound 4, shift of the target's melting temperature: 5.9 degrees C
Beside the measured number, compound 4's estimate is 1.4 degrees C below it, within the range that was stated.
By their numbers in this assay, from the lowest: compound 1; then compound 3; then compound 4; then compound 2.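

In this assay, for the compounds shown here, the aromatic carbon para to a large group responds to what it carries: trifluoromethoxy in place of butyl gives a number 1.3 degrees C higher from compound 3 to compound 4 (beyond the scatter) as the first single-place change that can be read here. The reading therefore survives, and rises modestly, when a four-carbon chain gives way to a group carrying oxygen and fluorine. Nothing available explains this rise. From the compounds shown here alone, whether an amine, a carboxylic acid or a chain longer than butyl at this same place would raise or lower the reading remains open.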